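Dropping One Chloro from a Dichloropurine Benzyl Series

The compounds below may be only part of what the source reports. "The series", "measured", "known", "first", "only" and "open" are said of these compounds alone.

Three benzyl-purines were tested in a functional assay on SNB-75 cells (Homo sapiens) for cytotoxicity, read by sulforhodamine B assay, with a stated time of 48 h; a higher number here means a weaker inhibitor of growth, a lower number a stronger inhibitor of growth. Compound 1 `ClCc1cccc(Cn2cnc3c(Cl)nc(Cl)nc32)c1` gives 2040 nM, compound 2 `Nc1nc(Cl)c2ncn(Cc3ccc(CCl)cc3)c2n1` gives 22900 nM, and compound 3 `ClCc1ccccc1Cn1cnc2nc(Cl)nc(Cl)c21` gives 1900 nM. Compound 3 has the lowest number of the three; compound 1 lies within the scatter of it, while compound 2 sits beyond the scatter, above both. Compound 4 `ClCc1ccccc1Cn1cnc2ncnc(Cl)c21` differs from compound 3 by hydrogen in place of chloro on an aromatic carbon. Going by the values given here, no measured pair shows this change, so its size is uncertain; the two dichloro compounds cluster together and only compound 2, with a different group, falls far off. A modest weakening is expected, giving a step of a 1.8-fold higher number from compound 3 to compound 4 (0.27 log units; within the scatter). Compound 4 is estimated at 3500 nM, within 1200 nM to 10000 nM.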

Compound 4, concentration for 50% growth inhibition: 11200 nM
Estimate against measurement, compound 4: 3.2-fold (0.51 log units) below; measured number outside the range, above it.
By their numbers in this assay, from the lowest: compounds 3 and 1 (each within the scatter of the next); then compound 4; then compound 2.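

In this assay, hydrogen in place of chloro on the aromatic carbon between two ring nitrogen atoms gives a 5.9-fold higher number from compound 3 to compound 4 (0.77 log units; beyond the scatter). Going by these compounds alone, this is the first change in a single place here, and it shows that this chloro matters for growth inhibition, since the step lies beyond the scatter. No measurement here explains the loss. On these data alone, whether an amine or a methoxy group on this carbon would keep the strength of the chloro remains open. So does whether the same change would give a similar step on the core of compound 1.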